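A few compounds are considered here, and "the series" means these few. Any claim that something is new, unique, unknown or untested is made for them only; others in the source may bear on it.

Three compounds have been measured in a functional assay on BXPC-3 cells (Homo sapiens) for antiproliferative activity, read by MTT assay, with a stated time of 24 h; on this read-out lower numbers stand for stronger inhibition and higher numbers for weaker inhibition:

compound 1 `CCn1c(C(=O)NCC(=O)OC)ccc1C(CC)(CC)c1ccc(OCS(=O)(=O)c2ccccc2)c(C)c1`, 20000 nM
compound 2 `CCn1c(C(=O)N[C@@H](CC(=O)OC)C(=O)OC)ccc1C(CC)(CC)c1ccc(OCS(=O)(=O)c2ccccc2)c(C)c1`, for which only a limit of > 50000 nM is recorded
compound 3 `CCn1c(C(=O)N[C@H](CO)CCO)ccc1C(CC)(CC)c1ccc(OCS(=O)(=O)c2ccccc2)c(C)c1`, 15900 nM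

Compound 1 gives the highest of the two plain numbers; its nearest neighbour is compound 3, with a 1.3-fold lower number from compound 1 to compound 3 (0.10 log units; within the scatter). The one clear movement is an at least 2.5-fold higher number from compound 1 to compound 2 (0.39 log units; beyond the scatter), although compound 2 sits at the limit of > 50000 nM in this assay, at which 1 of the 3 values shown sits, so that step can only be bounded.

Compound 4 `CCn1c(C(=O)N[C@@H](CO)CCO)ccc1C(CC)(CC)c1ccc(OCS(=O)(=O)c2ccccc2)c(C)c1` is still unmeasured. Its change from compound 1 is 3-hydroxy-1-(hydroxymethyl)propyl in place of (methoxycarbonyl)methyl on an amide-type nitrogen. This is the very same exchange that leads from compound 1 to compound 3, the only distinction being the handedness of the one defined stereocentre. That measured step was a 1.3-fold lower number from compound 1 to compound 3 (0.10 log units; within the scatter), and from the limit of compound 2 the move an at least 3.1-fold lower number from compound 2 to compound 3 (0.49 log units; beyond the scatter) points the same way. Nothing here separates the two handednesses, so no step beyond the scatter is expected: the estimate for compound 4 is 18000 nM, within 7000 nM to 45000 nM, which means an expected step of a 1.1-fold lower number from compound 1 to compound 4 (0.05 log units; within the scatter).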

Compound 4, half-maximal inhibitory concentration: > 50000 nM
Compound 4 ended at the assay's limit; the forecaster's own chance of this, stated with the estimate: 15%; middle value at least 2.7-fold (0.44 log units) away from the limit.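

Handedness at this position counts in this assay, with an at least 3.1-fold higher number from compound 3 to compound 4 (0.49 log units; beyond the scatter), and configuration alone accounts for that gap: the fact that compounds 3 and 4 differ only in the configuration as drawn.
The exchange of (methoxycarbonyl)methyl for 3-hydroxy-1-(hydroxymethyl)propyl on the amide-type nitrogen therefore has no single outcome: in one handedness it gives a 1.3-fold lower number from compound 1 to compound 3 (0.10 log units; within the scatter), while in the other it gives an at least 2.5-fold higher number from compound 1 to compound 4 (0.39 log units; beyond the scatter).
Among the compounds shown here, the reading for compound 4 is a limit and not a number, as is the one for compound 2, so the step between those two cannot be read: the limit of > 50000 nM in this assay, at which 2 of the 4 values shown sit.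

From the compounds shown here alone, whether a carboxylic acid or an amine at the end of this chain would depend on handedness in the same way stays open. Going by these compounds, the full size of the gap between the two mirror-drawn forms stays open as well.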